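The source may report more compounds than this note shows. Statements on the series, on what has been measured and on what is new or still open speak of the compounds shown alone.

In a functional assay on MV4-11 cells (Homo sapiens) for inhibition, read by resazurin assay, with a stated time of 72 h (on this read-out higher numbers stand for weaker inhibition of growth and lower numbers for stronger inhibition of growth), three compounds that differ in one group on an aromatic carbon have been measured. Compound 1 `Cc1ccc(-c2cncc(Cl)c2N2CCC3(CCNC3=O)CC2)s1` gives 650 nM, compound 2 `Cc1cc(-c2cncc(Cl)c2N2CCC3(CCNC3=O)CC2)sc1C=O` gives 2530 nM and compound 3 `Cn1cccc1-c1cncc(Cl)c1N1CCC2(CCNC2=O)CC1` gives 900 nM, the second highest of the three numbers. Compound 4 `O=C1NCCC12CCN(c1c(Cl)cncc1-c1cnn(C(F)F)c1)CC2` carries 1-(difluoromethyl)-1H-pyrazol-4-yl in place of 1-methyl-1H-pyrrol-2-yl on an aromatic carbon. The measured swaps at this place are small: a 1.4-fold higher number from compound 1 to compound 3 (0.14 log units; within the scatter) lies within the scatter, whereas a 3.9-fold higher number from compound 1 to compound 2 (0.59 log units; beyond the scatter) and a 2.8-fold lower number from compound 2 to compound 3 (0.45 log units; beyond the scatter) are modest steps beyond it. Among the measured compounds shown here, none of the measured compounds carries a pyrazole, so the direction is uncertain. The expected change is small, a 1.2-fold higher number from compound 3 to compound 4 (0.09 log units; within the scatter), probably within the scatter. For compound 4 the estimated value is 1100 nM, with an expected range of 400 nM to 3000 nM.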

Compound 4, concentration for 50% growth inhibition: 6140 nM
For compound 4 the middle estimate is 5.6-fold (0.75 log units) below the measured one; measured number outside the range, above it.
By their numbers in this assay, from the lowest: compounds 1 and 3 (each within the scatter of the next); then compound 2; then compound 4.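

Five-membered aromatic rings on this carbon are not interchangeable: the pyrazole brings a clear loss of growth inhibition (with a 6.8-fold higher number from compound 3 to compound 4 (0.83 log units; beyond the scatter)), although the thiophene of compound 1 and the pyrrole of compound 3 stand within the scatter of each other. The loss also holds against both thiophenes (with a 2.4-fold higher number from compound 2 to compound 4 (0.39 log units; beyond the scatter) and a 9.4-fold higher number from compound 1 to compound 4 (0.98 log units; beyond the scatter)), leaving compound 4 with the highest number of the four. Nothing available accounts for this loss.

The compounds shown do not separate the pyrazole ring from its difluoromethyl group. On these data alone, how a 1-methyl-1H-pyrazol-4-yl group or a simple amine on this carbon would compare remains open.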